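Trimming a Carbamate to a Hydroxy Group in Liver Microsomes

The source may hold more compounds than are shown below. What is called first, only, known or untested is meant among the compounds shown, and "the series" means these compounds.

Three compounds from this study were tested in an ADME assay on microsomes from liver (Homo sapiens) for metabolic stability, read by LC-MS, with NADPH named in the record, with a stated time of 60 min, tested at 1 uM, in the absence of a further agent; on this read-out lower numbers stand for a less stable compound and higher numbers for a more stable compound. Compound 1 `COc1ccc(-c2c(C)sc3c(N4CC[C@@H](NC(C)=O)C4)nc(C)nc23)cc1OC` gives > 95%, which is a limit of the assay rather than a measured number. Compound 2 `CC(=O)N[C@@H]1CCN(c2cc(C)nn3c(-c4ccc5cc[nH]c5c4)c(C)nc23)C1` also gives a limit, > 95%. Compound 3 `COc1ccc(-c2c(C)nc3c(N4CC[C@@H](NC(=O)OC5CCCCC5)C4)cc(C)nn23)cc1OC` sits at a limit as well, giving > 95%. Compound 3 therefore stands where every measured compound stands, namely at the limit of > 95% in this assay, at which 3 of the 3 values shown sit; nothing separates the three on this read-out.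

Compound 4 `COc1ccc(-c2c(C)nc3c(N4CC[C@@H](O)C4)cc(C)nn23)cc1OC` has not yet been measured. It differs from compound 3 in one place: hydroxy in place of (cyclohexyloxycarbonyl)amino on a saturated ring carbon. Among the measured compounds shown here, no step between two measured compounds is known here, so the size of this change cannot be taken from the data. Because all three measured compounds rest at the limit of > 95% in this assay, at which 3 of the 3 values shown sit, no room exists for an upward move, and a downward move is not expected. The step in this assay is expected to stay within the scatter: a number no higher from compound 3 to compound 4 (the limit leaves the size open). Compound 4 is expected to give 95%, between 85% and 100%, most likely reported again only as a limit.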

Compound 4, percent of the compound remaining: > 95%
Compound 4 was reported as a limit; the forecaster's own chance of this, stated with the estimate: 75%; the middle value lies on the limit itself.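

In this assay compound 4 gives > 95%, which is a limit of the assay. Among the compounds shown here, compound 3 also sits at a limit, so no step between compound 3 and compound 4 can be read. How the four compounds rank in stability stays open, because none of them gives an actual number: the limit of > 95% in this assay, at which 4 of the 4 values shown sit.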